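This account rests on a few compounds, and the source may have more. Where it says the series, first, only, none or still open, it means among the compounds named here.

In a functional assay on IMR-32 cells (Homo sapiens) for antiproliferative activity, read by MTT assay (on this read-out higher numbers stand for weaker inhibition and lower numbers for stronger inhibition), compound 1 (`Cc1c(-n2cc(COc3ccc(/C=C/C(=O)c4cc5c(cc4O)OC(C)(C)CC5)cc3)nn2)cccc1[N+](=O)[O-]`) stands as "not active" (no number reported), which leaves no number to step from. Compound 4 (`CCCCCCCCn1cc(COc2ccc(/C=C/C(=O)c3cc4c(cc3O)OC(C)(C)CC4)cc2)nn1`) carries octyl in place of 2-methyl-3-nitrophenyl on an aromatic nitrogen. In this assay compound 2 (`Cc1c(-n2cc(COc3ccc(/C=C/C(=O)c4ccc5c(c4O)CCC(C)(C)O5)cc3)nn2)cccc1[N+](=O)[O-]`) gives 73500 nM, and compound 3 (`COc1ccc(-n2cc(COc3ccc(/C=C/C(=O)c4ccc5c(c4O)CCC(C)(C)O5)cc3)nn2)c([N+](=O)[O-])c1`) gives 132000 nM. Going by the values given here, the one measured step at that kind of place, 4-methoxy-2-nitrophenyl in place of 2-methyl-3-nitrophenyl, is a 1.8-fold higher number from compound 2 to compound 3 (0.25 log units; within the scatter). Among the compounds with values here, it only trades one substituted phenyl for another, and no measured step covers an octyl group. Within the data shown here, no step of defined size can therefore be expected, and weak inhibition at best is the expectation in this assay. The estimated value for compound 4 is 70000 nM, with an expected range of 20000 nM to 200000 nM.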

Compound 4, half-maximal inhibitory concentration: 7090 nM
Compound 4: middle estimate off by 9.9-fold (0.99 log units), on the high side; measured number outside the range, below it.
By their numbers in this assay, from the lowest: compound 4; then compounds 2 and 3 (each within the scatter of the next).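

Going by these compounds alone, no step from compound 1 to compound 4 can be read in this assay, as compound 1 has no number there. The compounds shown leave open how much octyl itself contributes to the value of compound 4. No evidence on hand bears on this result.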